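Switching the aryl group on the thiazolidine core

The source may report more compounds than this note shows. Statements on the series, on what has been measured and on what is new or still open speak of the compounds shown alone.

Measured compounds:
compound 1 `CCCCCCCCCCCCCCCCCCNC(=O)[C@H]1CSC(c2cccc(O)c2)N1` gives 1200 nM
compound 2 `CCCCCCCCCCCCCCCCCCNC(=O)[C@H]1CSC(c2c(Cl)cccc2Cl)N1` gives 17100 nM
compound 3 `CCCCCCCCCCCCCCCCCCNC(=O)[C@H]1CSC(c2ccc(F)c(Br)c2)N1` gives 4700 nM

In a functional assay on PPC-1 cells (Homo sapiens) for antiproliferative activity, read by sulforhodamine B assay (on this read-out lower numbers stand for stronger inhibition and higher numbers for weaker inhibition), compound 3 stands second highest of the three numbers; compound 2 sits at a 3.6-fold lower number from compound 2 to compound 3 (0.56 log units; beyond the scatter) and compound 1 at a 3.9-fold higher number from compound 1 to compound 3 (0.59 log units; beyond the scatter). Compound 4 `CCCCCCCCCCCCCCCCCCNC(=O)[C@H]1CSC(c2ccc(C)cc2)N1` is not yet measured. Its change is 4-methylphenyl in place of 3-bromo-4-fluorophenyl on a saturated ring carbon. Going by the values given here, no measured step swaps in a methyl-bearing aryl group, so the bearing steps are only the two aryl swaps ending at compound 3, both modest in size. Exchanging one halogen-bearing aryl group for a plain methyl-bearing one is expected to move this assay little, so compound 4 is estimated at 4000 nM, within 1500 nM to 12000 nM, a step of a 1.2-fold lower number from compound 3 to compound 4 (0.07 log units; within the scatter).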

Compound 4, half-maximal inhibitory concentration: 1900 nM
Estimate against measurement, compound 4: 2.1-fold (0.32 log units) above; the range from low to high includes it.
By their numbers in this assay, from the lowest: compounds 1 and 4 (each within the scatter of the next); then compound 3; then compound 2.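

In this assay, the plain 4-methylphenyl group gives a lower number than either halogen-bearing aryl group, with a 2.5-fold lower number from compound 3 to compound 4 (0.39 log units; beyond the scatter) and a 9.0-fold lower number from compound 2 to compound 4 (0.95 log units; beyond the scatter). The step to the hydroxyl-bearing aryl group, a 1.6-fold higher number from compound 1 to compound 4 (0.20 log units; within the scatter), shows that 3-hydroxyphenyl is not the only aryl group among these compounds to reach this range. Nothing available explains these differences. On these data alone, it remains open whether an aryl group carrying an amine or a carboxylic acid would stay in this range or leave it.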